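This account rests on a few compounds, and the source may have more. Where it says the series, first, only, none or still open, it means among the compounds named here.

In a functional assay on SK-OV-3 cells (Homo sapiens) for cytotoxicity, read by MTT assay, with a stated time of 3 days (on this read-out higher numbers stand for weaker inhibition and lower numbers for stronger inhibition), compound 1 `N#Cc1c(-c2ccccc2)nc(SCc2nc3ccccc3[nH]2)nc1N1CCNCC1` gives 2.63 nM, compound 2 `N#Cc1c(-c2ccccc2)nc(SCc2nc3ccccc3[nH]2)nc1N1CCN(S(=O)(=O)c2ccccc2)CC1` gives 2.77 nM and compound 3 `Cc1ccc(S(=O)(=O)N2CCN(c3nc(SCc4nc5ccccc5[nH]4)nc(-c4ccccc4)c3C#N)CC2)cc1` gives 4.54 nM, so compound 3 stands level with the other two within the scatter. Compound 4 `N#Cc1c(-c2ccccc2)nc(SCc2nc3ccccc3[nH]2)nc1N1CCN(S(=O)(=O)c2ccccc2[N+](=O)[O-])CC1` departs from compound 3 by this change: 2-nitrophenyl in place of 4-methylphenyl on a sulfonyl sulfur. Within the data shown here, three measured steps bear on it: a 1.1-fold higher number from compound 1 to compound 2 (0.02 log units; within the scatter), a 1.7-fold higher number from compound 1 to compound 3 (0.24 log units; within the scatter) and a 1.6-fold higher number from compound 2 to compound 3 (0.21 log units; within the scatter). Among the measured compounds shown here, all three stay within the scatter, but no measured compound carries 2-nitrophenyl, so the guide is only indirect. No step beyond the scatter is expected in this assay, and the expected step is a 1.3-fold lower number from compound 3 to compound 4 (0.11 log units; within the scatter). The estimate for compound 4 is 3.5 nM, with an expected range from 1.3 nM to 10 nM.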

Compound 4, half-maximal inhibitory concentration: 3.2 nM
Estimate against measurement, compound 4: 1.1-fold (0.04 log units) above; the range from low to high includes it.
By their numbers in this assay, from the lowest: compounds 1, 2, 4 and 3 (each within the scatter of the next).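

In this assay, the sulfonyl sulfur tolerates 2-nitrophenyl as well as 4-methylphenyl (a 1.4-fold lower number from compound 3 to compound 4 (0.15 log units; within the scatter)). Adding nitro to the phenylsulfonyl group also stays within the scatter (a 1.2-fold higher number from compound 2 to compound 4 (0.06 log units; within the scatter)), as does replacing the hydrogen on the ring nitrogen with the whole (2-nitrophenyl)sulfonyl group (a 1.2-fold higher number from compound 1 to compound 4 (0.09 log units; within the scatter)), so this position has yet to show any real change with three different sulfonyl groups. No supporting data are available to explain this flat result.

On these data alone, it remains open whether an amine or a carboxylic acid on the phenyl ring would shift the number beyond the scatter. The same question applies to a longer alkyl chain in place of that ring on the sulfonyl sulfur.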